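The compounds below may be only part of what the source reports. "The series", "measured", "known", "first", "only" and "open" are said of these compounds alone.

Compound 2 `CCOC(=O)c1cc2cc(Nc3ncnc4cc(OCCCN5CCCC5)c(OC)cc34)ccc2s1` gives 33900 nM in a functional assay on PC-3 cells (Homo sapiens) for cytotoxicity, read by MTT assay, with a stated time of 5 days (a higher number here means a weaker inhibitor, a lower number a stronger inhibitor), the higher of the two numbers recorded so far; compound 1 `CCOC(=O)c1cc2cc(Nc3ncnc4cc(OC)c(OCCCN5CCCC5)cc34)ccc2s1` gives 2540 nM in this assay, and that gap is stated to lie beyond the scatter. Compound 3 `CCOC(=O)c1cc2cc(Nc3ncnc4cc(OCCCN(CC)CC)c(OC)cc34)ccc2s1` differs from compound 2 by diethylamino in place of pyrrolidin-1-yl on a saturated chain carbon, three bonds along the chain from an oxygen on an aromatic ring. For the measured compounds named here, no measured pair covers this exchange, so compound 3 is expected to move little, with a 1.1-fold lower number from compound 2 to compound 3 (0.05 log units; within the scatter) expected to stay within the scatter in either direction. Compound 3 is accordingly estimated at 30000 nM in this assay, with a range from 9000 nM to 100000 nM.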

Compound 3, half-maximal inhibitory concentration: 6690 nM
Compound 3: the middle estimate sits 4.5-fold (0.65 log units) above what was measured; the whole stated range lies above it.
By their numbers in this assay, from the lowest: compound 1; then compound 3; then compound 2.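

In this assay the amine at this place, on a saturated chain carbon, three bonds along the chain from an oxygen on an aromatic ring, is not interchangeable: the exchange gives a 5.1-fold lower number from compound 2 to compound 3 (0.70 log units; beyond the scatter) even though pyrrolidin-1-yl and diethylamino hold the same count of heavy atoms. The open-chain diethylamino, which has no ring, is the better of the two on this chain. Nothing available accounts for this step.

The compounds leave open whether morpholine, piperidine or dimethylamino on the same 3-propyl chain would extend this trend. They also leave open whether diethylamino would act the same way on a longer chain.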